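This account rests on a few compounds, and the source may have more. Where it says the series, first, only, none or still open, it means among the compounds named here.

Measured compounds in a functional assay on MCF7 cells (Homo sapiens) for antiproliferative activity, read by MTT assay, with a stated time of 48 h; on this read-out lower numbers stand for stronger inhibition and higher numbers for weaker inhibition:

compound 1 `N=C(N)N/N=C(/C=C/c1ccc(Br)cc1)c1ccccc1`, 250 nM
compound 2 `Cc1ccc(/C=C/C(=N/NC(=N)N)c2ccccc2)cc1`, 16000 nM
compound 3 `N=C(N)N/N=C(/C=C/c1ccccc1)c1ccc(Br)cc1`, 90 nM

Compound 3 sits lowest of the three, with compound 1 nearest and compound 2 furthest. Compound 1 and compound 3 share the same atoms joined differently; the difference between the two cores is not broken down here. Compound 1 and compound 2 differ by methyl in place of bromo on an aromatic carbon, and the step of a 64-fold higher number from compound 1 to compound 2 (1.81 log units; beyond the scatter) is large.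

Compound 4 `Cc1ccc(C(/C=C/c2ccccc2)=N\NC(=N)N)cc1` is not yet measured in this assay. It differs from compound 3 by methyl in place of bromo on an aromatic carbon, the same change as that from compound 1 to compound 2, at a place described in the same words. For the measured compounds named here, only one measured example of this change exists, on a different core, so its size on the core of compound 3 is uncertain. The step from compound 3 to compound 4 is expected to be a sizeable weakening, a 33-fold higher number from compound 3 to compound 4 (1.52 log units; beyond the scatter), resting on compound 1 to compound 2 a 64-fold higher number from compound 1 to compound 2 (1.81 log units; beyond the scatter); a somewhat smaller shift is allowed for, since the change moves to another core. Compound 4 is estimated at 3000 nM, between 600 nM and 15000 nM.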

Compound 4, half-maximal inhibitory concentration: 14000 nM
Compound 4: middle estimate off by 4.7-fold (0.67 log units), on the low side, within the range that was stated.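

In this assay methyl in place of bromo on the core of compound 3 gives a 160-fold higher number from compound 3 to compound 4 (2.19 log units; beyond the scatter), so the large weakening seen on the core of compound 1 appears here too. The size of the change carries across these two cores, and the two steps cannot be told apart: the same change on two cores in this assay, a 64-fold higher number (1.81 log units; beyond the scatter) from compound 1 to compound 2 and a 160-fold higher number (2.19 log units; beyond the scatter) from compound 3 to compound 4, 2.4-fold (0.39 log units) apart, within the scatter of two such steps. For the compounds shown here, this shows that, within this pair of cores, the bromo compound gives the far lower number on each, but it rests on only two steps and does not show that the change would carry to any other core, nor does it say why bromo and methyl differ so widely.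

The compounds shown leave open whether this gap is particular to bromo and methyl, since a chloro, a methoxy, an amine or a carboxylic acid on the same aromatic carbon would be needed to tell. Also open, as far as these compounds go, is how either core behaves with plain hydrogen at that place, which would show whether bromo raises or methyl lowers the activity.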